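Trimethoxy replacement on the benzyl ether aryl ring

A few compounds are considered here, and "the series" means these few. Any claim that something is new, unique, unknown or untested is made for them only; others in the source may bear on it.

Among the measured compounds shown here, compound 1 `Cc1cccc(COc2ccc(-c3cc(CN4CCN(Cc5ccc(C(F)(F)F)cc5)CC4)no3)cc2)c1` gives 2500 nM in a functional assay on Mahlavu cells (Homo sapiens) for antiproliferative activity, read by sulforhodamine B assay, with a stated time of 72 h (a lower number here means a stronger inhibitor, a higher number a weaker inhibitor), the lowest of the three numbers so far. Compound 3 `Fc1cccc(COc2ccc(-c3cc(CN4CCN(Cc5ccc(C(F)(F)F)cc5)CC4)no3)cc2)c1` sits closest, at 2900 nM; the step of a 1.2-fold higher number from compound 1 to compound 3 (0.06 log units; within the scatter) is within the scatter, so the two are not separated. Compound 2 `N#Cc1cccc(COc2ccc(-c3cc(CN4CCN(Cc5ccc(C(F)(F)F)cc5)CC4)no3)cc2)c1` gives 10600 nM, with a 4.2-fold higher number from compound 1 to compound 2 (0.63 log units; beyond the scatter) and, seen from the other side, a 3.7-fold lower number from compound 2 to compound 3 (0.56 log units; beyond the scatter).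

Compound 4 `COc1cc(COc2ccc(-c3cc(CN4CCN(Cc5ccc(C(F)(F)F)cc5)CC4)no3)cc2)cc(OC)c1OC` is reached from compound 1 by 3,4,5-trimethoxyphenyl in place of 3-methylphenyl on a saturated chain carbon bound to an oxygen on an aromatic ring. The measured steps all swap a single group on the same aryl ring: cyano in place of methyl cost a modest amount, fluoro in place of methyl cost nothing beyond the scatter. None of them adds three acceptors or enlarges the ring substitution as compound 4 does, so they bear on it only loosely; they suggest that changes on this ring shift the number by a modest amount at most, in the weaker direction when at all.

The step of a 1.5-fold higher number from compound 1 to compound 4 (0.18 log units; within the scatter) is therefore expected to be small, toward a higher number, with wide uncertainty. Compound 4 is estimated at 3800 nM, within 1300 nM to 11000 nM.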

Compound 4, half-maximal inhibitory concentration: 5800 nM
Compound 4: middle estimate off by 1.5-fold (0.18 log units), on the low side; low and high end bracket the measured number.
By their numbers in this assay, from the lowest: compounds 1, 3, 4 and 2 (each within the scatter of the next, the first and the last beyond it).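

On the saturated chain carbon bound to an oxygen on an aromatic ring, 3,4,5-trimethoxyphenyl stays in the range of the singly substituted phenyl groups in this assay, although it brings 12 heavy atoms and 3 hydrogen-bond acceptors. Against the 3-methylphenyl group the loss is modest (a 2.3-fold higher number from compound 1 to compound 4 (0.37 log units; beyond the scatter)), whereas compound 4 is not separated from either of the other two (a 2.0-fold higher number from compound 3 to compound 4 (0.30 log units; within the scatter); a 1.8-fold lower number from compound 2 to compound 4 (0.26 log units; within the scatter)). None of the three replacements of 3-methylphenyl gives a lower number beyond the scatter, and no measurement at hand explains the size of these steps.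

The compounds shown do not separate the share of each methoxy group, since a single methoxy on this phenyl ring is absent from them. From the compounds shown here alone, how an amine or a carboxylic acid on this ring would move the number also remains open.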